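The source may hold more compounds than are shown below. What is called first, only, known or untested is meant among the compounds shown, and "the series" means these compounds.

Three compounds have been measured in a functional assay on SMMC-7721 cells (Homo sapiens) for inhibition, read by CCK-8 assay, with a stated time of 72 h, tested at 2 uM; a lower number here means less inhibition of growth, a higher number more inhibition of growth at the concentration tested:

compound 1, `Nc1ccccc1NC(=O)/C=C/c1ccc(CSc2ccc(F)cc2)cc1`: 18.3%
compound 2, `Cc1ccc(SCc2ccc(C(=O)Nc3ccccc3N)cc2)cc1`: 25.1%
compound 3, `Nc1ccccc1NC(=O)c1ccc(CSc2cccc(F)c2)cc1`: 18.6%

The three numbers lie within the usual scatter of one another; compound 3 is the nearest to compound 1 and compound 2 the furthest, but none of them can be set apart from the rest. Going by the values given here, the one step measured so far that changes the ring on the sulfur, a number 6.5 percentage points lower from compound 2 to compound 3 (within the scatter), stayed within the scatter.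

Compound 4, `Nc1ccccc1NC(=O)/C=C/c1ccc(CSc2ccc(C(F)(F)F)cn2)cc1`, is the next compound to be measured. It differs from compound 1 in one place: 5-(trifluoromethyl)pyridin-2-yl in place of 4-fluorophenyl on a sulfur. Among the compounds with values here, this change is of the same kind as the one between compound 2 and compound 3, a different ring on the sulfur, and that step was within the scatter. Because of a number 6.5 percentage points lower from compound 2 to compound 3 (within the scatter) no step beyond the scatter is expected here either. Compound 4 is therefore expected to give 19%, in a range from 8% to 32%. The expected step of a number 0.7 percentage points higher from compound 1 to compound 4 (within the scatter) is estimated to lie within the scatter.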

Compound 4, percent growth inhibition at one concentration: 12.1%
Estimate against measurement, compound 4: 6.9 percentage points above, within the range that was stated.
By their numbers in this assay, from the lowest: compounds 4, 1, 3 and 2 (each within the scatter of the next, the first and the last beyond it).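

On the sulfur of compound 1, this assay now shows a change of a different order from the earlier one: a carbon-only ring gives way to 5-(trifluoromethyl)pyridin-2-yl, which has more heavy atoms, a ring hetero atom and a hydrogen-bond acceptor. Even so, the result is a number 6.2 percentage points lower from compound 1 to compound 4 (within the scatter), so this position tolerates that replacement without a step that can be told from the scatter, as it did for the smaller change a number 6.5 percentage points lower from compound 2 to compound 3 (within the scatter). Nothing available explains this result.

The compounds shown leave open whether any group on the sulfur can move the number beyond the scatter, since all of them carry an aromatic ring there. A ring bearing an amine or a carboxylic acid, or a saturated chain in place of the ring, might answer that.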